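A few compounds are considered here, and "the series" means these few. Any claim that something is new, unique, unknown or untested is made for them only; others in the source may bear on it.

Working notes on the series. Among the measured compounds shown here, compound 1 `O=C(Nc1cccc(-n2cc(-c3ccncc3)c(-c3cc(O)cc(Cl)c3)n2)c1)Nc1ccc(Cl)c(C(F)(F)F)c1` gives, in a functional assay on SW-620 cells (Homo sapiens) for inhibition, read by sulforhodamine B assay, with a stated time of 48 h, tested at 0.1 uM (on this read-out lower numbers stand for a stronger effect and higher numbers for a weaker effect at the one concentration tested), 98%, the lowest of the two numbers so far. Compound 2 `O=C(Nc1cccc(-n2cc(-c3ccncc3)c(-c3cc(O)cc(Cl)c3)n2)c1)Nc1ccc(Cl)c(Cl)c1` gives 99%; the step of a number 1 percentage points higher from compound 1 to compound 2 (within the scatter) is the only measured one, and it concerns a different position. Compound 3 `COc1cc(Cl)cc(-c2nn(-c3cccc(NC(=O)Nc4ccc(Cl)c(C(F)(F)F)c4)c3)cc2-c2ccncc2)c1` differs from compound 1 by methyl in place of hydrogen on an oxygen on an aromatic ring. For the measured compounds named here, no measured step covers this change, so nothing beyond the scatter is expected: a number 1 percentage points lower from compound 1 to compound 3 (within the scatter) is the estimated step. Compound 3 is therefore expected to give about 97%, in the range 85% to 105%.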

Compound 3, a percentage reported as activity, at one concentration (the size of the read-out at that concentration, not a potency): 96%
The estimate for compound 3 lay 1 percentage points above the measured number; the range from low to high includes it.
By their numbers in this assay, from the lowest: compounds 3, 1 and 2 (each within the scatter of the next).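

Hydroxy to methoxy is the first change measured at this position, and in this assay it gives a number 2 percentage points lower from compound 1 to compound 3 (within the scatter) at the one concentration tested. The hydrogen on this oxygen of compound 1 can thus be replaced by methyl with no step beyond the scatter. No measurement available here offers an explanation for this result.

On these data alone, whether a longer chain on this oxygen, such as ethoxy, or an amine in place of the hydroxy would leave the number within the scatter stays open. So does the outcome of this change with other groups in place of the chloro and trifluoromethyl on the urea's aryl ring.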